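Swapping the aryl ether substituent on a guanidine series

The compounds below may be only part of what the source reports. "The series", "measured", "known", "first", "only" and "open" are said of these compounds alone.

Measured so far:
- Compound 1, `CN(Cc1ccc(OCCCNC(=N)N)cc1)c1nc2ccc(Oc3ccc(C(F)(F)F)cc3)cc2s1`: 185000 nM
- Compound 2, `CN(Cc1ccc(OCCCNC(=N)N)cc1)c1nc2ccc(Oc3cccc(C(F)(F)F)c3)cc2s1`: 202000 nM

Both numbers come from an assay on SH-SY5Y cells for inhibition of Voltage-dependent N-type calcium channel subunit alpha-1B (Homo sapiens), read by FLIPR and calcium flux, with stated times of 600 s and 300 s, in the presence of a further agent that is not named here; a lower number here means a stronger inhibitor, a higher number a weaker inhibitor. Compound 2 gives the higher of the two numbers, but the step of a 1.1-fold higher number from compound 1 to compound 2 (0.04 log units; within the scatter) is within the scatter, so the two compounds cannot be told apart. Compound 3, `CN(Cc1ccc(OCCCNC(=N)N)cc1)c1nc2ccc(Oc3ccc(C#N)cc3)cc2s1`, differs from compound 2 by 4-cyanophenyl in place of 3-(trifluoromethyl)phenyl on an oxygen on an aromatic ring. Among the compounds with values here, no measured step changes the group itself; the one step seen only moves the trifluoromethyl around the ring, and it was flat. With nothing pointing either way, compound 3 is expected to stay near compound 2, with an estimated step of a 1.1-fold higher number from compound 2 to compound 3 (0.04 log units; within the scatter), giving an estimate of 220000 nM within 70000 nM to 700000 nM.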

Compound 3, half-maximal inhibitory concentration: 143000 nM
Compound 3: middle estimate off by 1.5-fold (0.19 log units), on the high side, and the stated range covers the measured number.
By their numbers in this assay, from the lowest: compounds 3, 1 and 2 (each within the scatter of the next).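

In this assay, cyano on the same aromatic carbon in place of trifluoromethyl gives a small shift (a 1.3-fold lower number from compound 1 to compound 3 (0.11 log units; within the scatter)), and changing both the group and its place on the ring gives another (a 1.4-fold lower number from compound 2 to compound 3 (0.15 log units; within the scatter)). Both shifts are within the scatter, so this position tolerates a change of group as well as a move around the ring, with no detectable effect on the number. Nothing measured here offers an explanation.

As far as these compounds go, whether an amine or a carboxylic acid on this ring would do the same remains open. So does whether a longer chain to the guanidine would move the number further than any change at this ether.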